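A few compounds are considered here, and "the series" means these few. Any claim that something is new, unique, unknown or untested is made for them only; others in the source may bear on it.

Series notes. The shared core is carried by compound 2 `COc1cc2ccc(=O)oc2cc1OCC1CO1`, compound 3 `COc1cc2ccc(=O)oc2cc1OCCNC(C)C` and compound 1 `COc1cc2ccc(=O)oc2cc1OCC(=O)c1ccc(Cl)c(Cl)c1`. In a functional assay on HUVEC cells (Homo sapiens) for inhibition, read by MTT assay, with a stated time of 24 h, tested at 10 uM (on this read-out higher numbers stand for more inhibition of growth at the one concentration tested and lower numbers for less inhibition of growth), compound 2 gives 62.2%, the highest of the three numbers. In this assay compound 3 gives 0.1% and compound 1 gives 0%, each beyond the scatter below compound 2. Among the measured compounds shown here, the one single-site step within the measured set is a number 62.1 percentage points lower from compound 2 to compound 3 (beyond the scatter).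

Compound 4 `COc1cc2ccc(=O)oc2cc1OCC(O)CNC(C)C` is not yet measured in this assay. It differs from compound 2 in one place: 1-hydroxy-2-(isopropylamino)ethyl in place of oxiran-2-yl on a saturated chain carbon bound to an oxygen on an aromatic ring The step from compound 2 to compound 3 bears on this, since in compound 4 the oxiran-2-yl again leaves and the entering group again carries an isopropylamino. The hydroxyl within the entering group has no parallel among the measured compounds, so its own contribution cannot be read off. Compound 3 shows where the series lands once the oxiran-2-yl is gone, at 0.1%. A drop of comparable size is therefore expected for compound 4, a number 52.2 percentage points lower from compound 2 to compound 4 (beyond the scatter). Compound 4 is estimated at 10%, with a range from 0% to 35%. The measured number in this assay will settle it.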

Compound 4, percent growth inhibition at one concentration: 0.1%
Compound 4: the middle estimate sits 9.9 percentage points above what was measured; low and high end bracket the measured number.
By their numbers in this assay, from the lowest: compounds 1, 3 and 4 (each within the scatter of the next); then compound 2.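

In this assay, the step of a number 62.1 percentage points lower from compound 2 to compound 4 (beyond the scatter) shows that an isopropylamino group carried on a chain with a hydroxyl, in place of the oxiran-2-yl, does not retain the inhibition of growth seen with compound 2. The hydroxyl, which could not be judged earlier, can now be read against its closest neighbour, no change at the digits printed from compound 3 to compound 4 (within the scatter), so at this position 1-hydroxy-2-(isopropylamino)ethyl and (isopropylamino)methyl cannot be told apart on this read-out, though with both numbers close to no inhibition, any contribution of the hydroxyl could stay hidden. No data at hand explain why either entering group gives so much less inhibition than the oxiran-2-yl.

The compounds shown leave open whether the three-membered ring itself is what compound 2 depends on, a question that an aziridine ring or a 2,3-dihydroxypropyl chain at the same place would address. They also leave open whether the hydroxyl would register on a chain without the isopropylamino group, and how compound 2 behaves at other concentrations.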